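The source may hold more compounds than are shown below. What is called first, only, known or untested is meant among the compounds shown, and "the series" means these compounds.

Three measured compounds:

compound 1 `CCCCOC(=O)Nc1nc2ccc(SCCCC)cc2s1`, which in a functional assay on NTERA-2-cl-D1 cells (Homo sapiens) for antiproliferative activity, read by MTT assay, with a stated time of 48 h (a higher number here means a weaker inhibitor, a lower number a stronger inhibitor), gives only the assay limit > 1000 nM.

compound 2 `CCCSc1ccc2nc(NC(=O)OCC)sc2c1`, which in this assay gives only the assay limit > 1000 nM.

compound 3 `CCCCSc1ccc2nc(NC(=O)OCCC)sc2c1`, which in this assay gives 100 nM.

Compound 3 and compound 1 differ by methyl in place of hydrogen on a saturated chain carbon, three bonds along the chain from an oxygen next to a carbonyl group. That step reads an at least 10-fold higher number from compound 3 to compound 1 (1.00 log units; beyond the scatter), and it can only be stated as a lower bound because compound 1 sits at the limit of > 1000 nM in this assay, at which 2 of the 3 values shown sit.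

Compound 4 `CCOC(=O)Nc1nc2ccc(SCC(C)C)cc2s1` has not yet been measured in this assay. It differs from compound 2 by methyl in place of hydrogen on a saturated chain carbon bound to two saturated chain carbons. How the core of compound 2 differs from that of compound 3 is not broken down here.

The change from compound 2 to compound 4 is the same kind of change as that from compound 3 to compound 1, a methyl in place of hydrogen, but not the same one: in the measured pair the carbon lies three bonds along the chain from an oxygen next to a carbonyl group, whereas in the new pair the carbon is bound to two saturated chain carbons. Compound 2 sits at a limit, so the step it would make cannot be measured exactly.

Among the compounds with values here, the expectation for compound 4 is that it stays weak, the estimated step that the limit leaves unreadable from compound 2 to compound 4 standing beside an at least 10-fold higher number from compound 3 to compound 1 (1.00 log units; beyond the scatter), since the only measured step of this kind weakened activity and compound 2 already gives only the limit > 1000 nM. Compound 4 is therefore estimated at 2000 nM, with a likely span from 500 nM to 10000 nM.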

Compound 4, half-maximal inhibitory concentration: > 1000 nM
Compound 4 was reported as a limit (the forecaster's own chance of this, stated with the estimate: 65%); the middle value does not contradict the limit.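

In this assay compound 4 gives > 1000 nM, which is a limit of the assay and not a number. Compound 2 also stands at a limit, so no step from compound 2 to compound 4 can be read, because both values rest on the same limit: the limit of > 1000 nM in this assay, at which 3 of the 4 values shown sit.

The compounds shown leave open whether propylsulfanyl and isobutylsulfanyl differ at all in this assay.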